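The compounds below may be only part of what the source reports. "The series", "measured", "known", "first", "only" and "open" are said of these compounds alone.

Series notes. Compound 1 `COC(=O)[C@@]1(C)CCC=C2[C@@H]1CC[C@@H](C)[C@]2(C)Cc1c[nH]c2ccc(C)cc12` and compound 3 `COC(=O)[C@@]1(C)CCC=C2[C@@H]1CC[C@@H](C)[C@]2(C)Cc1c(C)[nH]c2c(C)cccc12` have cores that differ in more than one place; the difference between the two cores is not broken down here. In a functional assay on HeLa cells (Homo sapiens) for inhibition, read by sulforhodamine B assay, with a stated time of 48 h (on this read-out lower numbers stand for stronger inhibition of growth and higher numbers for weaker inhibition of growth), compound 1 gives 14000 nM, and compound 3 gives 14000 nM. Compound 2 `COC(=O)[C@@]1(C)CCC=C2[C@@H]1CC[C@@H](C)[C@]2(C)Cc1c[nH]c2ccc(Br)cc12` comes from compound 1 by one change, (bromo in place of methyl on an aromatic carbon); in this assay compound 2 gives 10000 nM, which is a 1.4-fold lower number from compound 1 to compound 2 (0.15 log units; within the scatter). Compound 4 `COC(=O)[C@@]1(C)CCC=C2[C@@H]1CC[C@@H](C)[C@]2(C)Cc1c(C)[nH]c2c(Br)cccc12` stands to compound 3 in the same way: bromo in place of methyl on an aromatic carbon. The surroundings differ, though: the first change sits meta to a fused ring and para to a fused ring, the second ortho to a fused ring and meta to a fused ring, so this is the same kind of change rather than the same change. Because the earlier step was a 1.4-fold lower number from compound 1 to compound 2 (0.15 log units; within the scatter), a step of similar size is expected for compound 4, a 1.4-fold lower number from compound 3 to compound 4 (0.15 log units; within the scatter). Compound 4 is therefore estimated at 10000 nM in this assay, with an expected range of 4000 nM to 25000 nM.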

Compound 4, concentration for 50% growth inhibition: 22000 nM
Compound 4: middle estimate off by 2.2-fold (0.34 log units), on the low side; low and high end bracket the measured number.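

In this assay, bromo in place of methyl on the core of compound 3 gives a 1.6-fold higher number from compound 3 to compound 4 (0.20 log units; within the scatter). Set beside the earlier step, the two cores show no difference that this read-out can separate: the same change on two cores in this assay, a 1.4-fold lower number (0.15 log units; within the scatter) from compound 1 to compound 2 and a 1.6-fold higher number (0.20 log units; within the scatter) from compound 3 to compound 4, 2.2-fold (0.34 log units) apart, within the scatter of two such steps. This gives no sign that the change behaves differently from one core to the other, but it does not show that the change carries over as a fixed step: both steps are small, the two sites differ, and a modest effect of either core or site could go unseen within the scatter.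

The compounds shown carry only methyl and bromo at these aromatic carbons. From the compounds shown here alone, it remains open whether another group there, such as an amine, a carboxylic acid or a longer chain, would move the number beyond the scatter.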